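A few compounds are considered here, and "the series" means these few. Any claim that something is new, unique, unknown or untested is made for them only; others in the source may bear on it.

Going by the values given here, compound 2, `O=C(CN1CCC(c2cccc[n+]2[O-])CC1)Nc1cccc(Cl)c1`, stands at the lower end of the two numbers known so far: in a functional assay on HEK293 cells for agonist activity at D(4) dopamine receptor (Homo sapiens), read by FLIPR (a higher number here means that more compound is needed for the effect, a lower number that less compound is needed), compound 2 gives 62 nM, while compound 1, `O=C(CN1CCC(c2cccc[n+]2[O-])CC1)NC1CCCCC1`, gives 294 nM. Among the compounds with values here, the one measured step, a 4.7-fold lower number from compound 1 to compound 2 (0.68 log units; beyond the scatter), came from exchanging cyclohexyl for 3-chlorophenyl on the amide-type nitrogen.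

Compound 3, `CSc1cccc(NC(=O)CN2CCC(c3cccc[n+]3[O-])CC2)c1`, keeps that 3-chlorophenyl framework but differs from compound 2 by methylsulfanyl in place of chloro on an aromatic carbon. Within the data shown here, no measured step speaks directly to an exchange of one substituent for another on this aromatic ring; the only step available concerns the whole group on the amide nitrogen, and it shows that this part of the molecule can move the number modestly. A substituent swap of this kind is therefore expected to stay close to compound 2, with no step beyond the scatter in either direction; the step from compound 2 to compound 3 is estimated as a 1.5-fold higher number from compound 2 to compound 3 (0.16 log units; within the scatter). For compound 3 the expected value in this assay is 90 nM, within a range from 30 nM to 270 nM.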

Compound 3, half-maximal effective concentration: 100 nM
Compound 3: the middle estimate sits 1.1-fold (0.05 log units) below what was measured; measured number inside the range.
By their numbers in this assay, from the lowest: compounds 2 and 3 (each within the scatter of the next); then compound 1.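

In this assay, going by these compounds alone, the exchange of chloro for methylsulfanyl on this aromatic carbon gives the first reading of a substituent change at this place on the ring (a 1.6-fold higher number from compound 2 to compound 3 (0.21 log units; within the scatter)), and because that step lies within the scatter, the two groups cannot be told apart here. The lower number relative to the cyclohexyl amide of compound 1 now holds for two different substituents on the phenyl ring, since the step to the 3-(methylsulfanyl)phenyl amide (a 2.9-fold lower number from compound 1 to compound 3 (0.47 log units; beyond the scatter)) lies beyond the scatter, as does the step to the 3-chlorophenyl amide (a 4.7-fold lower number from compound 1 to compound 2 (0.68 log units; beyond the scatter)), and neither compound goes against this. Nothing available offers an explanation for this behaviour at the position.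

The compounds shown leave open whether this place tolerates groups of a different kind, such as an amine, a carboxylic acid or a longer chain like butylsulfanyl, as evenly as it does chloro and methylsulfanyl. They also leave open whether methylsulfanyl would read the same on another carbon of the ring, or whether an unsubstituted phenyl amide would already account for the lower number.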